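Extending compound 3 with a butyl group

This account rests on a few compounds, and the source may have more. Where it says the series, first, only, none or still open, it means among the compounds named here.

In a toxicity assay on Hepa-1c1c7 cells (Mus musculus) for inhibition (a higher number here means a weaker inhibitor, a lower number a stronger inhibitor), compound 1 (`CCCCCC(O)C#CC#CC(O)CCC`) gives 19000 nM, compound 2 (`CCCCCCCCCC(O)C#CC#CC(O)CCC`) gives 30000 nM and compound 3 (`CCCCCCCCCC(O)C#CC#CC(O)CCCCC`) gives 12000 nM. Compound 3 stands apart from only one of the others: the data show a 2.5-fold lower number from compound 2 to compound 3 (0.40 log units; beyond the scatter), but only a 1.6-fold lower number from compound 1 to compound 3 (0.20 log units; within the scatter).

Compound 4 (`CCCCCCCCCC(O)C#CC#CC(O)CCCCCCCCC`) has not yet been measured. Its structure departs from that of compound 3 by a single change: butyl in place of hydrogen on a saturated chain carbon, six bonds along the chain from an oxygen on a saturated carbon and a triple-bonded carbon. Going by the values given here, the closest precedent is the same replacement of hydrogen by butyl, with a 1.6-fold higher number from compound 1 to compound 2 (0.20 log units; within the scatter). That step stayed within the scatter, so no step beyond the scatter is expected in this assay. The precedent was measured on a different partner, however, and the ethyl step shown above was modest yet real, so the range is kept wide. The expected step is a 1.3-fold higher number from compound 3 to compound 4 (0.10 log units; within the scatter). For compound 4 the estimated value is 15000 nM, with an expected range of 6000 nM to 40000 nM.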

Compound 4, half-maximal inhibitory concentration: 26000 nM
The estimate for compound 4 lay 1.7-fold (0.24 log units) below the measured number, within the range that was stated.
By their numbers in this assay, from the lowest: compounds 3, 1, 4 and 2 (each within the scatter of the next, the first and the last beyond it).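

In this assay, the butyl change now gives a step beyond the scatter on the core of compound 3, a 2.2-fold higher number from compound 3 to compound 4 (0.34 log units; beyond the scatter), which its earlier precedent did not, yet the two butyl steps still cannot be told apart: the same change on two cores in this assay, a 1.6-fold higher number (0.20 log units; within the scatter) from compound 1 to compound 2 and a 2.2-fold higher number (0.34 log units; beyond the scatter) from compound 3 to compound 4, 1.4-fold (0.14 log units) apart, within the scatter of two such steps. The hexyl change, read on the core of compound 2, gives a 1.2-fold lower number from compound 2 to compound 4 (0.06 log units; within the scatter), and it agrees with its earlier counterpart: the same change on two cores in this assay, a 1.6-fold lower number (0.20 log units; within the scatter) from compound 1 to compound 3 and a 1.2-fold lower number (0.06 log units; within the scatter) from compound 2 to compound 4, 1.4-fold (0.14 log units) apart, within the scatter of two such steps. Across these four compounds, then, each change reads alike on both cores, and neither shows a dependence on the chain carried elsewhere in the molecule.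

The compounds shown leave open whether a longer chain in place of butyl, on the same saturated chain carbon, would continue the step. They also leave open what an amine or a carboxylic acid there would do.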